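This account rests on a few compounds, and the source may have more. Where it says the series, first, only, none or still open, it means among the compounds named here.

Compound 1 `CCCCCCCCCC[n+]1cccc(OP(=O)([O-])OC[C@H]2O[C@@H](n3cc(F)c(=O)[nH]c3=O)C[C@@H]2OC(=O)c2ccccc2)c1`: 8730 nM
Compound 2 `O=C(O[C@H]1C[C@H](n2cc(F)c(=O)[nH]c2=O)O[C@@H]1COP(=O)([O-])Oc1ccc[n+](Cc2ccccc2)c1)c1ccccc1`: 3430 nM

Both values come from a functional assay on T47D cells (Homo sapiens) for cytotoxicity, read by MTT assay, with a stated time of 48 h; on this read-out higher numbers stand for weaker inhibition and lower numbers for stronger inhibition. Compound 2 has the lower of the two numbers, and the gap to compound 1 lies beyond the usual scatter. The next compound, compound 3 `CCOC(=O)C[n+]1cccc(OP(=O)([O-])OC[C@H]2O[C@@H](n3cc(F)c(=O)[nH]c3=O)C[C@@H]2OC(=O)c2ccccc2)c1`, has not yet been measured. It shares its core with compound 2 and differs in one group: ethoxycarbonyl in place of phenyl on a saturated chain carbon bound to an aromatic nitrogen.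

Among the measured compounds shown here, only one measured step bears on this place: a 2.5-fold lower number from compound 1 to compound 2 (0.41 log units; beyond the scatter), seen when phenyl replaced nonyl. It shows that a change here can move the number, but it says nothing directly about ethoxycarbonyl, and two compounds cannot establish a trend. Going by a 2.5-fold lower number from compound 1 to compound 2 (0.41 log units; beyond the scatter), a step of about that size or smaller is expected in this assay, more likely toward a higher number, and it may stay within the scatter. The estimated change is a 1.6-fold higher number from compound 2 to compound 3 (0.21 log units; within the scatter). For compound 3 the estimated value is 5500 nM, with an expected range from 1800 nM to 16000 nM.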

Compound 3, half-maximal inhibitory concentration: 12700 nM
The estimate for compound 3 lay 2.3-fold (0.36 log units) below the measured number, within the range that was stated.
By their numbers in this assay, from the lowest: compound 2; then compounds 1 and 3 (each within the scatter of the next).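

In this assay, replacing phenyl with ethoxycarbonyl on the saturated chain carbon bound to the aromatic nitrogen gives a 3.7-fold higher number from compound 2 to compound 3 (0.57 log units; beyond the scatter), so the gain seen with phenyl does not carry over to this ringless group. Placing ethoxycarbonyl in the same position instead of nonyl gives a 1.5-fold higher number from compound 1 to compound 3 (0.16 log units; within the scatter), which means that these two quite different groups cannot be told apart in this assay. Among the three compounds, only compound 2, the one with the benzyl group, stands clearly apart from the other two, although nothing here explains why.

Among the compounds shown here, with only one ring-bearing group in the set, it remains open whether any aromatic ring would keep the lower number, or whether this depends on phenyl itself, as a pyridine ring or a chlorophenyl group could help to show. It is also unknown how a carboxylic acid or an amine at this place would compare, or whether a chain shorter or longer than nonyl would differ from the nonyl group of compound 1.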